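Methoxy to fluoro in a macrocycle and its open analog

This account rests on a few compounds, and the source may have more. Where it says the series, first, only, none or still open, it means among the compounds named here.

Compound 1 `COc1ccc2c(c1)-c1cnc(n1C)OCCCCCCCCO2` carries a methoxy group on a benzene ring within a three-ring system closed by a long chain. In a functional assay on SK-MEL-28 cells (Homo sapiens) for inhibition, read by colorimetric assay and MTT assay, with a stated time of 72 h (a lower number here means a stronger inhibitor, a higher number a weaker inhibitor), compound 1 gives 57000 nM. Compound 2 `Cn1c2cnc1OCCCCCCCCOc1ccc(F)cc1-2` differs from compound 1 in one place: fluoro in place of methoxy on an aromatic carbon. In this assay compound 2 gives 72000 nM. That change gave a 1.3-fold higher number from compound 1 to compound 2 (0.10 log units; within the scatter). Compound 3 `C=CCCCCOc1ccc(OC)cc1-c1cnc(OCCC=C)n1C` keeps the methoxy group but has the ring opened into two chains; in this assay compound 3 gives 62000 nM. How the core of compound 3 differs from the core of compound 1 is not broken down here; the two values lie close together. Compound 4 `C=CCCCCOc1ccc(F)cc1-c1cnc(OCCC=C)n1C` has not been measured. It differs from compound 3 by the same kind of change: fluoro in place of methoxy on an aromatic carbon. The surroundings are not identical: in compound 1 the carbon is meta to a fused ring and para to a fused ring, whereas in compound 3 it is meta to a large group and para to a (hex-5-en-1-yl)oxy group. A similarly small step is expected here because the earlier change gave a 1.3-fold higher number from compound 1 to compound 2 (0.10 log units; within the scatter). The expected step is a 1.3-fold higher number from compound 3 to compound 4 (0.10 log units; within the scatter). Compound 4 is therefore estimated at 78000 nM, likely between 40000 nM and 150000 nM.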

Compound 4, half-maximal inhibitory concentration: 82000 nM
Estimate against measurement, compound 4: 1.1-fold (0.02 log units) below; the range from low to high includes it.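

In this assay, fluoro in place of methoxy on the core with two open chains gave a 1.3-fold higher number from compound 3 to compound 4 (0.12 log units; within the scatter). Set beside the same change on the closed macrocycle, the two steps agree: the same change on two cores in this assay, a 1.3-fold higher number (0.10 log units; within the scatter) from compound 1 to compound 2 and a 1.3-fold higher number (0.12 log units; within the scatter) from compound 3 to compound 4, 1.0-fold (0.02 log units) apart, within the scatter of two such steps This shows that, across these two cores, the change carries over as a small step that cannot be told apart from the ordinary noise of the measurement, but it does not show that fluoro and methoxy truly differ in this assay, nor that a larger step would transfer as faithfully, since only two pairs of compounds are available.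

The compounds shown leave open what other groups would do at this place on the ring, such as an amine, a carboxylic acid or a plain hydrogen, and what a longer chain would do in place of the (hex-5-en-1-yl)oxy group. As far as these compounds go, it also stays open whether the same agreement would hold on a core whose numbers are much lower than these.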